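The source may report more compounds than this note shows. Statements on the series, on what has been measured and on what is new or still open speak of the compounds shown alone.

Measured in a functional assay on L1210 cells (Mus musculus) for cytotoxicity, with a stated time of 48 h; on this read-out higher numbers stand for weaker inhibition and lower numbers for stronger inhibition:

Compound 1, `Clc1ccc(Cc2nn3cc(-c4ccccc4)nc3s2)cc1`. For compound 1 the result is a limit of the assay, > 250000 nM.
Compound 2, `O=Cc1c(-c2ccc(Br)cc2)nc2sc(Cc3ccc(Cl)cc3)nn12`, gives 4600 nM.
Compound 3, `COc1ccc(-c2nc3sc(Cc4ccc(Cl)cc4)nn3c2C=O)cc1`, gives 5300 nM.

Among the two numbers that are not limits, compound 3 holds the higher one, and its nearest neighbour is compound 2; the step of a 1.2-fold higher number from compound 2 to compound 3 (0.06 log units; within the scatter) lies within the scatter.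

Compound 4, `O=Cc1c(-c2ccccc2)nc2sc(Cc3ccc(Cl)cc3)nn12`, differs from compound 3 by hydrogen in place of methoxy on an aromatic carbon. Among the measured compounds shown here, only one measured step touches the same ring: a 1.2-fold higher number from compound 2 to compound 3 (0.06 log units; within the scatter), which swapped one group for another at that place without moving the number beyond the scatter. Removing the methoxy is therefore expected to change this assay little, with a 1.1-fold lower number from compound 3 to compound 4 (0.03 log units; within the scatter). Compound 4 is estimated at 5000 nM, between 2000 nM and 13000 nM.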

Compound 4, half-maximal inhibitory concentration: 20000 nM
Compound 4: middle estimate off by 4.0-fold (0.60 log units), on the low side; the whole stated range lies below it.
By their numbers in this assay, from the lowest: compounds 2 and 3 (each within the scatter of the next); then compound 4. At a limit, above all of these: compound 1.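

At this place on the phenyl ring, para to a large group, the substituent does register in this assay: methoxy and bromo read alike, yet hydrogen gives a 3.8-fold higher number from compound 3 to compound 4 (0.58 log units; beyond the scatter) and a 4.3-fold higher number from compound 2 to compound 4 (0.64 log units; beyond the scatter). Even without a substituent there, adding the formyl to the core gives an at least 12-fold lower number from compound 1 to compound 4 (1.09 log units; beyond the scatter). That step is only a bound, since compound 1 stands at a limit: the limit of > 250000 nM in this assay, at which 1 of the 4 values shown sits.

Only methoxy, bromo and hydrogen are shown at this place. On these data alone, how an amine or a carboxylic acid there would read stays open.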